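The compounds below may be only part of what the source reports. "The series", "measured", "known", "first", "only" and "open" are said of these compounds alone.

Notes on the step from compound 2 to compound 3. Two compounds carry numbers in a functional assay on PC-3 cells (Homo sapiens) for inhibition; on this read-out higher numbers stand for weaker inhibition and lower numbers for stronger inhibition. Compound 1 `COc1cc2nc(N3CCN(S(=O)(=O)c4ccc(OC(F)(F)F)cc4)CC3)nc(N)c2cc1OC` gives 25000 nM. Among the measured compounds shown here, compound 2 `COc1cc2nc(N3CCN(S(=O)(=O)c4ccc(-c5ccc(C(F)(F)F)cc5)cc4)CC3)nc(N)c2cc1OC` gives 3300 nM, the lower of the two numbers, and the step of a 7.6-fold lower number from compound 1 to compound 2 (0.88 log units; beyond the scatter) is the only measured step in the set. Compound 3 `COc1cc2nc(N3CCN(S(=O)(=O)c4ccc(-c5ccc(S(C)(=O)=O)cc5)cc4)CC3)nc(N)c2cc1OC` carries methylsulfonyl in place of trifluoromethyl on an aromatic carbon. For the measured compounds named here, no measured step changes a substituent on the 4-(trifluoromethyl)phenyl group, so the step from compound 1 to compound 2 does not bear directly on this change; it only shows that compound 2 holds the lowest number so far. In the absence of a comparable step, a change of at most modest size in this assay, in either direction, is expected for compound 3, with a number somewhat higher than that of compound 2 taken as the middle of the range. Compound 3 is estimated at 5000 nM, between 1500 nM and 20000 nM. The expected step is a 1.5-fold higher number from compound 2 to compound 3 (0.18 log units; within the scatter).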

Compound 3, half-maximal inhibitory concentration: 7200 nM
Compound 3: middle estimate off by 1.4-fold (0.16 log units), on the low side; measured number inside the range.
By their numbers in this assay, from the lowest: compound 2; then compound 3; then compound 1.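

In this assay, the group on the outer aromatic ring matters: methylsulfonyl in place of trifluoromethyl gives a 2.2-fold higher number from compound 2 to compound 3 (0.34 log units; beyond the scatter), a modest loss at this position, para to a large group. Even so, the 4-(methylsulfonyl)phenyl group keeps part of the advantage over trifluoromethoxy, with a 3.5-fold lower number from compound 1 to compound 3 (0.54 log units; beyond the scatter), so the lower number relative to compound 1 is not tied to trifluoromethyl alone. No measurement at hand accounts for the difference between these two groups.

With only two substituents compared on this aromatic carbon, no trend can be drawn from them. Going by these compounds, it remains open whether an amine, a carboxylic acid or a longer alkyl chain at this position would give a number below that of compound 2 or a higher one.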